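Flipping one ring stereocentre on the methyl analogue

The source may hold more compounds than are shown below. What is called first, only, known or untested is meant among the compounds shown, and "the series" means these compounds.

Compound 1 `O=C([C@H]1C[C@H]1F)N1CC2CC(C1)N2`: 110%
Compound 2 `O=C([C@@H]1C[C@H]1F)N1CC2CC(C1)N2`: 110%
Compound 3 `C[C@@H]1C[C@@H]1C(=O)N1CC2CC(C1)N2`: 97%

In an assay on SH-EP1 cells for agonist activity at Neuronal acetylcholine receptor; alpha4/beta2 (Homo sapiens), read by FLIPR and calcium flux (on this read-out lower numbers stand for smaller maximal responses and higher numbers for larger maximal responses), compound 3 gives 97%, the lowest of the three numbers shown. The two fluoro-bearing compounds sit above it: a number 13 percentage points lower from compound 1 to compound 3 (beyond the scatter) and a number 13 percentage points lower from compound 2 to compound 3 (beyond the scatter), both steps beyond the scatter but modest in size. Compound 1 and compound 2 differ from each other only in the drawing of one stereocentre, as the fact that one of compounds 1 and 2 is drawn with a defined configuration and the other without, at the place where they differ records, and that pair shows no change at the digits printed from compound 1 to compound 2 (within the scatter).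

Compound 4 `C[C@@H]1C[C@H]1C(=O)N1CC2CC(C1)N2` is the not-yet-measured partner of compound 3. The difference between them is the two compounds have the same atoms and bonds; at least one stereo element is drawn with a configuration in one of them and without one in the other: 1 of 4 stereo elements differ; a stereocentre at a saturated ring carbon is drawn S in compound 3 and R in compound 4. For the measured compounds named here, this is the same kind of change as the one between compound 1 and compound 2, where the response did not move beyond the scatter. Going by the values given here, the only relevant measured step therefore points to no change, and the expected step is no change at the digits printed from compound 3 to compound 4 (within the scatter), within the usual scatter. Compound 4 is expected to give 97%, with a range from 82% to 112%.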

Compound 4, largest response reached (Emax), in percent of the reference or control that the assay uses: 110%
Beside the measured number, compound 4's estimate is 13 percentage points below it, and the stated range covers the measured number.
By their numbers in this assay, from the lowest: compound 3; then compounds 1, 2 and 4 (each within the scatter of the next).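

In this assay, the ring stereocentre turns out to matter on the methyl side, with a number 13 percentage points higher from compound 3 to compound 4 (beyond the scatter), although the same kind of flip left the fluoro pair unmoved. Methyl in place of fluoro also no longer reads as a general loss, with no change at the digits printed from compound 2 to compound 4 (within the scatter) and no change at the digits printed from compound 1 to compound 4 (within the scatter), so compound 3 alone stands apart from the other three. The two readings of that swap are not firmly in conflict, however: the same change on two cores in this assay, a number 13 percentage points lower (beyond the scatter) from compound 1 to compound 3 and no change at the digits printed (within the scatter) from compound 2 to compound 4, 13 percentage points apart, within the scatter of two such steps

These numbers cannot tell why the flip registers on the methyl pair and not on the fluoro pair. From the compounds shown here alone, it also remains open how the response would behave with a hydroxyl, an amine or an ethyl group on that ring carbon, in either stereo arrangement.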